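Adding 1-methylpiperidin-4-yl to compound 2

A few compounds are considered here, and "the series" means these few. Any claim that something is new, unique, unknown or untested is made for them only; others in the source may bear on it.

Three compounds have been measured in an assay on COS-7 cells for inhibition of tyrosine-protein kinase receptor UFO (Homo sapiens), read by ELISA, with a stated time of 1 h; a lower number here means a stronger inhibitor, a higher number a weaker inhibitor:

Compound 1 `Cc1nn(C)c(C)c1-c1ccc(-c2nnc(N(C)Cc3ccc4nccn4c3)o2)c(F)c1`: 3160 nM
Compound 2 `Cc1cc(-c2c(C)nn(C)c2C)ccc1-c1nnc(N(C)Cc2ccc3nccn3c2)o1`: 398 nM
Compound 3 `Cc1cc(-c2c(C)nn(C(F)F)c2C)ccc1-c1nnc(N(C)Cc2ccc3nccn3c2)o1` gives only a limit of the assay, > 10000 nM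

Compound 2 has the lowest of the two actual numbers. The step of a 7.9-fold lower number from compound 1 to compound 2 (0.90 log units; beyond the scatter) came from methyl in place of fluoro on an aromatic carbon; the step of an at least 25-fold higher number from compound 2 to compound 3 (1.40 log units; beyond the scatter) came from difluoromethyl in place of methyl on an aromatic nitrogen.

Compound 4 `Cc1cc(-c2c(C)nn(C)c2C)ccc1-c1nnc(N(C)Cc2ccc3ncc(C4CCN(C)CC4)n3c2)o1` differs from compound 2 by 1-methylpiperidin-4-yl in place of hydrogen on an aromatic carbon. Neither measured step touched the fused two-ring system, so neither bears directly on this change; no step beyond the scatter is expected, and the step of a 1.0-fold higher number from compound 2 to compound 4 (0.00 log units; within the scatter) is the estimate. For compound 4 the expected value in this assay is 400 nM, within 100 nM to 1600 nM.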

Compound 4, half-maximal inhibitory concentration: 1260 nM
Compound 4: the middle estimate sits 3.2-fold (0.50 log units) below what was measured; low and high end bracket the measured number.
By their numbers in this assay, from the lowest: compound 2; then compound 4; then compound 1. At a limit, above all of these: compound 3.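

Until now, no measured change had touched the fused two-ring system. Compound 4 shows that this aromatic carbon of the five-membered ring accepts 1-methylpiperidin-4-yl, with its 7 heavy atoms, at a modest cost: in this assay the change gives a 3.2-fold higher number from compound 2 to compound 4 (0.50 log units; beyond the scatter), and the potency that remains is still measurable. Nothing shown here accounts for this loss.

Still open, as far as these compounds go, is whether a morpholine ring or an open-chain amine such as dimethylaminomethyl would be tolerated at this carbon, and whether the piperidine needs its nitrogen methyl.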